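Acetamido for dimethylamino on a second naphthalene placement

A few compounds are considered here, and "the series" means these few. Any claim that something is new, unique, unknown or untested is made for them only; others in the source may bear on it.

Compound 1, `Cc1noc(NS(=O)(=O)c2cccc3ccc(N(C)C)cc23)c1C`: 5600 nM in an assay on thoracic aorta for binding affinity to Endothelin-1 receptor (Rattus norvegicus); a lower number here means a stronger inhibitor, a higher number a weaker inhibitor
Compound 2, `CC(=O)Nc1ccc2cccc(S(=O)(=O)Nc3onc(C)c3C)c2c1`: 870 nM in this assay
Compound 3, `Cc1noc(NS(=O)(=O)c2ccc3cccc(N(C)C)c3c2)c1C`: 31500 nM in this assay

Compound 3 shows the highest of the three numbers; compound 1 and compound 3 are built from the same atoms joined differently, and the difference between the two cores is not broken down here. The change from compound 1 to compound 2 is acetamido in place of dimethylamino on an aromatic carbon, and it gave a 6.4-fold lower number from compound 1 to compound 2 (0.81 log units; beyond the scatter).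

Compound 4, `CC(=O)Nc1cccc2ccc(S(=O)(=O)Nc3onc(C)c3C)cc12`, has not been measured. It differs from compound 3 by acetamido in place of dimethylamino on an aromatic carbon. This is the same kind of change as from compound 1 to compound 2, but not the same: there the group sat meta to a fused ring and para to a fused ring, here it sits ortho to a fused ring and meta to a fused ring. Compound 4 is expected to land near 5000 nM, between 1500 nM and 20000 nM, because the like change gave a 6.4-fold lower number from compound 1 to compound 2 (0.81 log units; beyond the scatter). The expected step is a 6.3-fold lower number from compound 3 to compound 4 (0.80 log units; beyond the scatter), with wide uncertainty since the place differs.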

Compound 4, half-maximal inhibitory concentration: 27500 nM
Estimate against measurement, compound 4: 5.5-fold (0.74 log units) below; the whole stated range lies below it.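

Putting acetamido in place of dimethylamino on the core of compound 3 gave a 1.1-fold lower number from compound 3 to compound 4 (0.06 log units; within the scatter) in this assay, so on this core the swap has no effect that can be told apart from the noise of the measurement. The lower number that the same swap produced on the core of compound 1 therefore did not carry over, and the two steps really do differ: the same change on two cores in this assay, a 6.4-fold lower number (0.81 log units; beyond the scatter) from compound 1 to compound 2 and a 1.1-fold lower number (0.06 log units; within the scatter) from compound 3 to compound 4, 5.6-fold (0.75 log units) apart, beyond the scatter of two such steps

What this does not show is why the two cores respond differently. Within the data shown here, with only two pairs, the result cannot say which feature of the cores matters, and it cannot predict how the swap would behave on a further core.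

The compounds shown leave open whether a plain amine or a methoxy group at the same place would follow the pattern of compound 1 and compound 2, or that of compound 3 and compound 4. A longer chain on the amide carbonyl remains an open question in the same way.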